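Fluoro to methyl on the amide-ring aryl: pyridyl series

This account rests on a few compounds, and the source may have more. Where it says the series, first, only, none or still open, it means among the compounds named here.

Measured compounds in a functional assay on HEK293 cells for positive allosteric modulation of metabotropic glutamate receptor 5 (Homo sapiens), read by calcium flux; on this read-out higher numbers stand for larger maximal responses and lower numbers for smaller maximal responses:
compound 1, `O=C1c2cc(COc3ccccc3)nn2CCN1c1ccc(F)cc1`, gives 79%;
compound 2, `Cc1ccc(N2CCn3nc(COc4ccccc4)cc3C2=O)cc1`, gives 65%;
compound 3, `O=C1c2cc(COc3ccccc3)nn2CCN1c1ccc(F)cn1`, gives 72%.

Compound 4, `Cc1ccc(N2CCn3nc(COc4ccccc4)cc3C2=O)nc1`, is not yet measured. Compound 3 differs from compound 1 by 5-fluoropyridin-2-yl in place of 4-fluorophenyl on an amide-type nitrogen in a ring, a swap of the aryl group on the amide-type nitrogen in a ring. The change from compound 1 to compound 2 is methyl in place of fluoro on an aromatic carbon; it made a step of a number 14 percentage points lower from compound 1 to compound 2 (beyond the scatter). The change from compound 3 to compound 4 is methyl in place of fluoro on an aromatic carbon, the same kind of change, but here on a six-membered aromatic ring with 1 nitrogen, two atoms from the ring nitrogen, where in compound 1 the ring is of carbon only. The cores agree otherwise. For the measured compounds named here, on the single earlier step, compound 4 is expected to sit lower than compound 3 by a number 12 percentage points lower from compound 3 to compound 4 (beyond the scatter), resting on the step from compound 1 to compound 2. Compound 4 is estimated at 60%, between 48% and 72%.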

Compound 4, largest response reached (Emax), in percent of the reference or control that the assay uses: 76%
Compound 4: middle estimate off by 16 percentage points, on the low side, and the stated range ends below it.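

In this assay, methyl in place of fluoro on the pyridyl ring gives a number 4 percentage points higher from compound 3 to compound 4 (within the scatter), so the drop seen on the phenyl ring does not recur here. The aryl swap gives a number 11 percentage points higher from compound 2 to compound 4 (beyond the scatter) with methyl on both rings, and the step that changes both the ring and its substituent gives a number 3 percentage points lower from compound 1 to compound 4 (within the scatter), a pair that cannot separate the two changes. With only one pair per core, this shows no rule for other cores and does not say what sets the gap, only that the step from fluoro to methyl did not carry across these two: the same change on two cores in this assay, a number 14 percentage points lower (beyond the scatter) from compound 1 to compound 2 and a number 4 percentage points higher (within the scatter) from compound 3 to compound 4, 18 percentage points apart, beyond the scatter of two such steps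

Going by these compounds, whether chloro, methoxy or trifluoromethyl in this place would follow the phenyl or the pyridyl pair remains open. So does whether a second ring nitrogen would change the picture.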